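A few compounds are considered here, and "the series" means these few. Any claim that something is new, unique, unknown or untested is made for them only; others in the source may bear on it.

Measured so far in an in vitro functional assay on cells for antagonist activity at metabotropic glutamate receptor 1 (Homo sapiens), read by FLIPR and calcium flux; on this read-out lower numbers stand for stronger inhibition and higher numbers for weaker inhibition:

- compound 1 `Cc1nc2c(cnn2-c2cccc(Cl)c2)c(=O)n1-c1ccc(Cl)cc1` gives 220 nM
- compound 2 `Cc1nc2c(cnn2-c2ccc(S(N)(=O)=O)cc2)c(=O)n1-c1ccc(Cl)cc1` gives 1410 nM

Compound 2 stands at the highest of the two numbers in this assay; compound 1 sits well below it, and the gap between the two lies beyond the usual scatter. Among the measured compounds shown here, no single-point step between measured compounds is available, so the pair shows only that the compound carrying the sulfamoyl group is the weaker inhibitor of the two.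

Compound 3 `Cc1nc2c(cnn2-c2ccc(Cl)cc2)c(=O)n1-c1ccc(Cl)cc1` is not yet measured. It differs from compound 2 by chloro in place of sulfamoyl on an aromatic carbon. For the measured compounds named here, the only guide is that the other chloro-bearing compound, compound 1, gives 220 nM in this assay, a clearly lower number than compound 2. On that basis compound 3 is expected to move down toward the region of compound 1, and the expected step from compound 2 to compound 3 is a decrease beyond the scatter, a 4.4-fold lower number from compound 2 to compound 3 (0.64 log units; beyond the scatter). In this assay, going by the values given here, compound 3 is estimated to give 320 nM, within a range of 110 nM to 950 nM, the range kept wide because only one comparison supports it.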

Compound 3, half-maximal inhibitory concentration: 1100 nM
Estimate against measurement, compound 3: 3.4-fold (0.54 log units) below; the whole stated range lies below it.
By their numbers in this assay, from the lowest: compound 1; then compounds 3 and 2 (each within the scatter of the next).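

In this assay, at this place on an aromatic carbon, para to a large group, chloro in place of sulfamoyl gives a 1.3-fold lower number from compound 2 to compound 3 (0.11 log units; within the scatter), so swapping a group of 4 heavy atoms with 1 hydrogen-bond donor for a single chlorine produces no readable change in this pair. The gap between compound 1 and compound 2 therefore cannot be read as a sulfamoyl penalty, since those two differ in more than one place, and the new comparison with a single difference lies elsewhere: 4-chlorophenyl in place of 3-chlorophenyl on an aromatic nitrogen gives a 5.0-fold higher number from compound 1 to compound 3 (0.70 log units; beyond the scatter), beyond the scatter, so where the chloro sits on this ring matters more in this assay than which of the two groups occupies the place para to a large group. Nothing measured here gives a cause for either step.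

On these data alone, with only chloro and sulfamoyl compared at this place, the response to an amine, a carboxylic acid or a methoxy group there remains open. Also open, as far as these compounds go, is whether sulfamoyl would match chloro at the ring position that chloro holds in compound 1, or whether the equivalence seen here is confined to the place para to a large group.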